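A Larger Ether on a Well-Tolerated Compound

This account rests on a few compounds, and the source may have more. Where it says the series, first, only, none or still open, it means among the compounds named here.

In an ADME assay on cells (Fibroblast, Gallus gallus) for cytotoxicity, read by CCK-8 assay, with a stated time of 48 h (a higher number here means that more compound is tolerated, a lower number that less compound is tolerated), compound 1 (`CCC(CC)O[C@@H]1C=C(C(=O)O)C[C@H](NCc2cccc(OC)c2)[C@H]1NC(C)=O`) gives > 200000 nM as its reading, which is a limit of the assay and not a number. Compound 2 (`CCC(CC)O[C@@H]1C=C(C(=O)O)C[C@H](NCc2ccc(OC(C)C)cc2)[C@H]1NC(C)=O`) gives > 200000 nM as its reading, again a limit. Compound 1 therefore has no exact place on the scale, and the data so far show only the limit of > 200000 nM in this assay, at which 2 of the 2 values shown sit, and nothing finer.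

Compound 3 (`CCC(CC)Oc1cccc(CN[C@H]2CC(C(=O)O)=C[C@@H](OC(CC)CC)[C@@H]2NC(C)=O)c1`) differs from compound 1 in one place, with pentan-3-yl in place of methyl on an oxygen on an aromatic ring. Among the measured compounds shown here, the only measured step that bears on this is a step that the two limits leave unreadable from compound 1 to compound 2 with 4-isopropoxyphenyl in place of 3-methoxyphenyl. Its size cannot be read, but it offers no sign that changing this kind of group moves the reading away from the limit. On that basis, no step beyond the usual scatter is expected in this assay and no direction can be assigned.

The expected change is a number no higher from compound 1 to compound 3 (the limit leaves the size open) as an estimate only. Compound 3 is estimated at 200000 nM within an expected range of 60000 nM to 400000 nM and may well report only a limit.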

Compound 3, half-maximal cytotoxic concentration: > 200000 nM
Compound 3: no number, only a limit; the forecaster's own chance of this, stated with the estimate: 75%; the middle value sits exactly at the limit.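

In this assay compound 3 gives > 200000 nM, which is again a limit and not a number. Among the compounds shown here, compound 1 also reads only as a limit, so no step from compound 1 to compound 3 can be read. The compounds shown leave open how much compound each one would take before a true reading appears: the limit of > 200000 nM in this assay, at which 3 of the 3 values shown sit.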